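Adding a Methyl at the Ring Nitrogen, Twice

The compounds below may be only part of what the source reports. "The series", "measured", "known", "first", "only" and "open" are said of these compounds alone.

Compound 1 `CN1CCN(CC(=O)O[C@@H]2C[C@@H]3CC[C@@]2(C)C3(C)C)CC1` and compound 3 `CCN1CCN(CC(=O)O[C@@H]2C[C@@H]3CC[C@@]2(C)C3(C)C)CC1` share one core and differ only by methyl in place of hydrogen on a saturated chain carbon bound to an amine nitrogen in a ring. In an ADME assay on HEK-293T cells (Homo sapiens) for cytotoxicity, read by MTT assay, with a stated time of 48 h (on this read-out higher numbers stand for lower toxicity in this test and lower numbers for higher toxicity in this test), compound 1 gives 313000 nM, while compound 3 gives 130000 nM. Compound 2 `CN1CCN(CCC(=O)O[C@@H]2C[C@@H]3CC[C@@]2(C)C3(C)C)CC1` rests on another core; the difference between the two cores is not broken down here. In this assay compound 2 gives 282000 nM. Compound 4 `CCN1CCN(CCC(=O)O[C@@H]2C[C@@H]3CC[C@@]2(C)C3(C)C)CC1` is not yet measured and differs from compound 2 by methyl in place of hydrogen on a saturated chain carbon bound to an amine nitrogen in a ring, the same change as from compound 1 to compound 3. Because that change gave a 2.4-fold lower number from compound 1 to compound 3 (0.38 log units; beyond the scatter), a step of similar size is expected from compound 2 to compound 4, roughly a 2.4-fold lower number from compound 2 to compound 4 (0.37 log units; beyond the scatter). Compound 4 is therefore estimated at 120000 nM in this assay, with 60000 nM to 240000 nM as the likely range.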

Compound 4, half-maximal cytotoxic concentration: 264000 nM
The estimate for compound 4 lay 2.2-fold (0.34 log units) below the measured number; measured number outside the range, above it.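

On the core of compound 2, the change gives a 1.1-fold lower number from compound 2 to compound 4 (0.03 log units; within the scatter). Set beside the earlier step, the result on this core cannot be told apart from the one on the core of compound 1 in this assay: the same change on two cores in this assay, a 2.4-fold lower number (0.38 log units; beyond the scatter) from compound 1 to compound 3 and a 1.1-fold lower number (0.03 log units; within the scatter) from compound 2 to compound 4, 2.3-fold (0.35 log units) apart, within the scatter of two such steps. This does not show that the change acts differently on the two cores, nor does it fix a step size that would carry over to a further core, as two pairs are too few for that.

The compounds shown leave open how a longer chain in the same place, such as propyl or butyl, would read in this assay. They also leave open what a ring group there, such as cyclopropyl or phenyl, would give.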